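The source may report more compounds than this note shows. Statements on the series, on what has been measured and on what is new or still open speak of the compounds shown alone.

Measured so far in an assay on HEK293 cells for displacement of a labelled ligand from NPC1-like intracellular cholesterol transporter 1 (Homo sapiens); on this read-out higher numbers stand for weaker inhibition and lower numbers for stronger inhibition:
- compound 1 `CC(C)(C)OC(=O)NCCNC(=O)CN1CN(c2ccccc2)C2(CCN(C(=O)c3ccc(C4CCCCC4)cc3)CC2)C1=O`: 5500 nM
- compound 2 `O=C(CN1CN(c2ccccc2)C2(CCN(C(=O)c3ccc(C4CCCCC4)cc3)CC2)C1=O)NCCO`: 2000 nM
- compound 3 `CS(=O)(=O)NCCNC(=O)CN1CN(c2ccccc2)C2(CCN(C(=O)c3ccc(C4CCCCC4)cc3)CC2)C1=O`: 2100 nM

Compound 3 stands second highest of the three numbers in this assay. Against compound 2 the difference is a 1.1-fold higher number from compound 2 to compound 3 (0.02 log units; within the scatter), within the scatter, so no order between these two is claimed; against compound 1 the step is a 2.6-fold lower number from compound 1 to compound 3 (0.42 log units; beyond the scatter).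

Compound 4 `CS(=O)(=O)N1CCN(C(=O)CN2CN(c3ccccc3)C3(CCN(C(=O)c4ccc(C5CCCCC5)cc4)CC3)C2=O)CC1` differs from compound 3 by 4-(methylsulfonyl)piperazin-1-yl in place of (2-(methanesulfonamido)ethyl)amino on a carbonyl carbon. All three measured steps act on the end of the same side chain: a 2.8-fold lower number from compound 1 to compound 2 (0.44 log units; beyond the scatter) and a 2.6-fold lower number from compound 1 to compound 3 (0.42 log units; beyond the scatter) are modest, while a 1.1-fold higher number from compound 2 to compound 3 (0.02 log units; within the scatter) lies within the scatter. None of them replaces the open chain end with a ring, so they bear on the new step only loosely. The working expectation is therefore a step of at most modest size in this assay, direction uncertain, most likely within the scatter. Compound 4 is estimated at 2500 nM, with a range from 1000 nM to 7000 nM, which means the expected step of a 1.2-fold higher number from compound 3 to compound 4 (0.08 log units; within the scatter).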

Compound 4, half-maximal inhibitory concentration: 6300 nM
Compound 4: the middle estimate sits 2.5-fold (0.40 log units) below what was measured; low and high end bracket the measured number.
By their numbers in this assay, from the lowest: compounds 2 and 3 (each within the scatter of the next); then compounds 1 and 4 (each within the scatter of the next).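

In this assay, this carbonyl carbon now shows a step on closing the chain end into a ring: a 3.0-fold higher number from compound 3 to compound 4 (0.48 log units; beyond the scatter), and a 3.2-fold higher number from compound 2 to compound 4 (0.50 log units; beyond the scatter), both modest. The methylsulfonyl group is present in both compound 3 and compound 4, so keeping it does not hold the number, while the hydrogen-bond donors of the leaving group are gone from the 4-(methylsulfonyl)piperazin-1-yl group. With a 1.1-fold higher number from compound 1 to compound 4 (0.06 log units; within the scatter), compound 4 falls level with compound 1 rather than with compound 2 or compound 3, and no available data explain this difference.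

Ring entry and donor loss occur together here, so which one goes with the step stays open. An N-methylated (2-(methanesulfonamido)ethyl)amino group or a morpholine amide would bear on that question, as would a piperazine with a free amine.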